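Propyl to octyl on compound 3

The compounds below may be only part of what the source reports. "The series", "measured", "known", "first", "only" and "open" are said of these compounds alone.

In a physicochemical assay for lipophilicity, measured as octanol-water partition (a lower number here means a more polar compound, a higher number a more lipophilic compound), compound 3 `CCCc1cn(C/C=C(/C)CC/C=C(\C)CCC=C(C)C)nn1` gives 6.5 as the middle of three numbers. Compound 1 `COC(=O)c1cn(C/C=C(/C)CC/C=C(\C)CCC=C(C)C)nn1` lies lower at 5.25 and compound 2 `CCCCCCCCc1cn(C/C=C(/C)CCC=C(C)C)nn1` higher at 6.92 with both gaps beyond the scatter. Compound 4 `CCCCCCCCc1cn(C/C=C(/C)CC/C=C(\C)CCC=C(C)C)nn1` differs from compound 3 by one change: pentyl in place of hydrogen on a saturated chain carbon, three bonds along the chain from an aromatic carbon in words, pentyl in place of hydrogen on a saturated chain carbon, three bonds along the chain from an aromatic carbon. Going by the values given here, the one measured step bearing on this is a number 1.25 log units higher from compound 1 to compound 3 (beyond the scatter) and it is large, though it is a different swap. Compound 2 already carries the octyl group on a shorter side chain. A large upward step is therefore expected in this assay and is estimated as a number 1.30 log units higher from compound 3 to compound 4 (beyond the scatter) for now. For compound 4 the estimate is 7.8 with an expected range from 7.1 to 8.6 as the likely span.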

Compound 4, partition coefficient: 8.76
Beside the measured number, compound 4's estimate is 0.96 log units below it; measured number outside the range, above it.
By their numbers in this assay, from the lowest: compound 1; then compound 3; then compound 2; then compound 4.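

In this assay, lengthening propyl to octyl on the aromatic carbon gives a number 2.26 log units higher from compound 3 to compound 4 (beyond the scatter), so chain length at this position carries a large step on the longer side chain. Octyl in place of methoxycarbonyl on the same carbon gives a number 3.51 log units higher from compound 1 to compound 4 (beyond the scatter). With octyl held fixed, 3-methylbut-2-en-1-yl in place of hydrogen on a saturated chain carbon bound to a double-bonded chain carbon gives a number 1.84 log units higher from compound 2 to compound 4 (beyond the scatter), so the far end of the side chain also moves this read-out.

Where an amine, a carboxylic acid or a chain longer than octyl on this carbon would fall remains open. Nothing measured accounts for the size of these steps.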